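Second chloro on the benzyl ring of compound 1

The source may hold more compounds than are shown below. What is called first, only, known or untested is meant among the compounds shown, and "the series" means these compounds.

Working notes on the series. Three compounds share one core and differ only in the amine carried on the saturated chain carbon bound to an aromatic carbon. Compound 1 `CN(C)Cc1ccc2nc(NC(=O)N/N=C/c3cn(Cc4ccc(Cl)cc4)c4ccccc34)sc2c1` gives in a functional assay on NCI-H460 cells (Homo sapiens) for cytotoxicity, read by MTT assay, with a stated time of 72 h (a higher number here means a weaker inhibitor, a lower number a stronger inhibitor), a value of 290 nM. Compound 2 `CC1CCN(Cc2ccc3nc(NC(=O)N/N=C/c4cn(Cc5ccc(Cl)cc5)c5ccccc45)sc3c2)CC1` gives 400 nM, and compound 3 `CCN(CC)Cc1ccc2nc(NC(=O)N/N=C/c3cn(Cc4ccc(Cl)cc4)c4ccccc34)sc2c1` gives 370 nM. The steps of a 1.4-fold higher number from compound 1 to compound 2 (0.14 log units; within the scatter) and a 1.3-fold higher number from compound 1 to compound 3 (0.11 log units; within the scatter) are both within the scatter, as is a 1.1-fold lower number from compound 2 to compound 3 (0.03 log units; within the scatter). Compound 1 therefore has the lowest of the three numbers, but its gaps to compound 3 and compound 2 are within the scatter, so no order among the three is claimed.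

Compound 4 `CN(C)Cc1ccc2nc(NC(=O)N/N=C/c3cn(Cc4ccc(Cl)c(Cl)c4)c4ccccc34)sc2c1` differs from compound 1 at another place: chloro in place of hydrogen on an aromatic carbon. Cut one bond further out, this reads 4-chlorobenzyl to 3,4-dichlorobenzyl. Among the measured compounds shown here, none of the measured steps touches this ring; all three vary the amine, and the amine changes themselves stayed within the scatter. For the measured compounds named here, there is thus no measured step that bears on the change, and no basis for expecting a step beyond the scatter in either direction.

For compound 4 the expected value in this assay is 290 nM, with a range from 120 nM to 700 nM. The expected step is accordingly no change at the digits printed from compound 1 to compound 4 (within the scatter), an estimate carrying wide uncertainty.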

Compound 4, half-maximal inhibitory concentration: 1360 nM
Compound 4: the middle estimate sits 4.7-fold (0.67 log units) below what was measured; measured number outside the range, above it.
By their numbers in this assay, from the lowest: compounds 1, 3 and 2 (each within the scatter of the next); then compound 4.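

Among the compounds shown here, the benzyl ring is the first place where a single change moves the number beyond the scatter in this assay: 4-chlorobenzyl to 3,4-dichlorobenzyl gives a 4.7-fold higher number from compound 1 to compound 4 (0.67 log units; beyond the scatter), and the higher number means a weaker inhibitor. All three amine swaps stayed within the scatter, so the flat response seen at the amine does not carry over to this aromatic carbon, ortho to a chloro group, where the entering group has only 1 heavy atom. No measurement at hand bears on the cause of this step.

The shown compounds cannot separate an effect of this position from an effect of chloro itself, which a fluoro or methyl group in place of the added chloro, or an unsubstituted benzyl group, would help to address. From the compounds shown here alone, it also remains open whether the step would have a similar size with diethylamino or 4-methylpiperidin-1-yl in place of dimethylamino, since 3,4-dichlorobenzyl appears here only with dimethylamino.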